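The source may report more compounds than this note shows. Statements on the series, on what has been measured and on what is new or still open speak of the compounds shown alone.

Of the compounds shown here, two have been tested in a functional assay on MIA PaCa-2 cells (Homo sapiens) for inhibition, read by MTT assay, with a stated time of 3 days; on this read-out lower numbers stand for stronger inhibition and higher numbers for weaker inhibition. Compound 1, `CCOC(=O)N1CCC[C@H](S(=O)(=O)c2ccc(S(=O)(=O)N(CC)CC)cc2)C1`, was run first in its own series of measurements. In this assay compound 1 gives > 10000 nM, which is a limit of the assay rather than a number. Compound 2, `CCOC(=O)[C@@H]1C[C@H](O)CN(S(=O)(=O)c2ccc(S(=O)(=O)N(CC)CC)cc2)C1`, shares the same terminal sulfonamide-bearing aromatic part but carries a hydroxyl and an ester on a different saturated ring. In this assay compound 2 gives > 10000 nM, again a limit and not a number. So compound 2 stands at the upper boundary of what the assay can report, and so does everything measured alongside it: the limit of > 10000 nM in this assay, at which 2 of the 2 values shown sit.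

The next compound, compound 3, `CCOC(=O)[C@@H]1C[C@@H](O)CN(S(=O)(=O)c2ccc(S(=O)(=O)N(CC)CC)cc2)C1`, is the mirror-image partner of compound 2 at one point: the two compounds have the same atoms and bonds and differ only in configuration as drawn: 1 of 2 stereo elements differ; a stereocentre at a saturated ring carbon is drawn S in compound 2 and R in compound 3. Among the measured compounds shown here, no step between two measured compounds is available to calibrate such a change. Because both measured values sit at the limit of > 10000 nM in this assay, at which 2 of the 2 values shown sit, no step beyond the scatter is expected in this assay, and the shift from compound 2 to compound 3 is estimated as a step that the limit leaves unreadable from compound 2 to compound 3. Compound 3 is therefore expected to come out near 15000 nM, in a range from 5000 nM to 50000 nM, most likely again as a limit.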

Compound 3, half-maximal inhibitory concentration: > 10000 nM
Compound 3: no number, only a limit; the forecaster's own chance of this, stated with the estimate: 85%; the middle value does not contradict the limit.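

No step can be read between compound 2 and compound 3, since in this assay each stands only at a limit and neither gives a number. The compounds shown leave open whether the configuration at that saturated ring carbon affects inhibition at all, and what change to this series would give a measurable value.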